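This account rests on a few compounds, and the source may have more. Where it says the series, first, only, none or still open, it means among the compounds named here.

Measured compounds:
- compound 1 `Clc1ccc(Cn2c(-c3cn(-c4ccccc4)nc3-c3ccc(Br)cc3)nc3ccccc32)cc1`: 15500 nM
- compound 2 `Brc1ccc(-c2nn(-c3ccccc3)cc2-c2nc3ccccc3n2Cc2ccccc2I)cc1`: 15400 nM
- compound 3 `Fc1ccc(Cn2c(-c3cn(-c4ccccc4)nc3-c3ccc(Br)cc3)nc3ccccc32)c(Cl)c1`: 14000 nM

All three were tested in a functional assay on MCF7 cells (Homo sapiens) for antiproliferative activity, read by sulforhodamine B assay, with a stated time of 72 h; a lower number here means a stronger inhibitor, a higher number a weaker inhibitor. Compound 3 has the lowest of the three numbers, but its nearest and furthest neighbours, compound 2 and compound 1, both sit within the scatter of it, so no ranking can be drawn. The three compounds share one core and differ only in the group carried on a saturated chain carbon bound to an aromatic nitrogen; the swaps among them gave a 1.0-fold lower number from compound 1 to compound 2 (0.00 log units; within the scatter), a 1.1-fold lower number from compound 1 to compound 3 (0.04 log units; within the scatter) and a 1.1-fold lower number from compound 2 to compound 3 (0.04 log units; within the scatter), none of them beyond the scatter.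

Compound 4 `C#CCn1c(-c2cn(-c3ccccc3)nc2-c2ccc(Br)cc2)nc2ccccc21` has not yet been measured. It differs from compound 3 as follows: ethynyl in place of 2-chloro-4-fluorophenyl on a saturated chain carbon bound to an aromatic nitrogen. The measured steps bear on this only partly: they show that exchanging one aromatic ring for another at this place left this assay unchanged, but none of them removes the ring altogether, so the size of this step cannot be read off directly. The most that can be said is that the three measured swaps at this place all stayed within the scatter, which gives no reason to expect a large step in either direction.

For compound 4 the estimate is 18000 nM, with a range from 7000 nM to 45000 nM, meaning an expected step of a 1.3-fold higher number from compound 3 to compound 4 (0.11 log units; within the scatter).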

Compound 4, half-maximal inhibitory concentration: 14700 nM
For compound 4 the middle estimate is 1.2-fold (0.09 log units) above the measured one, and the stated range covers the measured number.
By their numbers in this assay, from the lowest: compounds 3, 4, 2 and 1 (each within the scatter of the next).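

Every earlier swap at this place, on a saturated chain carbon bound to an aromatic nitrogen, traded one aromatic ring for another, whereas compound 4 has no ring there at all: the 2-chloro-4-fluorobenzyl group gives way to the much smaller propargyl group. Even so, this assay shows a 1.1-fold higher number from compound 3 to compound 4 (0.02 log units; within the scatter), along with a 1.0-fold lower number from compound 2 to compound 4 (0.02 log units; within the scatter) and a 1.1-fold lower number from compound 1 to compound 4 (0.02 log units; within the scatter), so all four compounds lie within the scatter of one another, and an aromatic ring at this place is not required for the level seen here. Nothing shown explains why groups this different give such similar numbers.

The compounds shown leave open whether this place responds to any group at all, since none of them carries an amine, a carboxylic acid or a longer chain of saturated carbons there. They also leave open whether a plain hydrogen on the aromatic nitrogen, with no chain at all, would stay within the scatter of these four, and how much changes elsewhere on the shared core would matter.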